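This account rests on a few compounds, and the source may have more. Where it says the series, first, only, none or still open, it means among the compounds named here.

Measured compounds:
compound 1, `O=C(COc1ccc2cc(C(O)(C(F)(F)F)C(F)(F)F)c(O)cc2c1)Nc1ccccc1`, in an assay on isolated protein for inhibition of receptor-type tyrosine-protein phosphatase C (Homo sapiens), read by spectrophotometry; on this read-out lower numbers stand for stronger inhibition and higher numbers for weaker inhibition: > 20000 nM
compound 2, `Oc1c(-c2ccccc2)cccc1C(O)(C(F)(F)F)C(F)(F)F`, in this assay: 157000 nM

Compound 1 carries a bis(trifluoromethyl)carbinol on a shared core, with an ether-linked acetamide bearing an anilide. In this assay compound 1 gives only a limit, > 20000 nM, and no number; it sits at the limit of > 20000 nM in this assay, at which 1 of the 2 values shown sits. Compound 2, which holds the same carbinol on a smaller core, gives in this assay a value of 157000 nM. Within the data shown here, no step between the two measured compounds is available, since they differ in more than one place, so their values can only be set side by side: both stand at the weak end of the read-out.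

Compound 3, `Cc1ccc(S(=O)(=O)NNC(=O)COc2ccc3cc(C(O)(C(F)(F)F)C(F)(F)F)c(O)cc3c2)cc1`, has not yet been measured in this assay. It differs from compound 1 by ((4-methylphenyl)sulfonyl)amino in place of phenyl on an amide-type nitrogen. Given that compound 1 shows only a limit, the step from compound 1 to compound 3 is expected to be small or to stay within the scatter, with a fair chance that compound 3 again reports only a limit; the expected change is a step that the limit leaves unreadable from compound 1 to compound 3. Compound 3 is therefore estimated at 40000 nM, with a range from 8000 nM to 200000 nM.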

Compound 3, half-maximal inhibitory concentration: 16100 nM
Beside the measured number, compound 3's estimate is 2.5-fold (0.40 log units) above it; low and high end bracket the measured number.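

With ((4-methylphenyl)sulfonyl)amino in place of phenyl on the amide-type nitrogen, this position on the shared core now has a measured number rather than a limit alone, and the change in this assay reads as an at least 1.2-fold lower number from compound 1 to compound 3 (0.09 log units; that floor lies within the scatter). That step is only a floor, so it shows neither a real gain from the change nor the absence of one: the true difference may lie within the scatter or well beyond it. The step cannot be sized more closely because compound 1 gives no number, only a limit: the limit of > 20000 nM in this assay, at which 1 of the 3 values shown sits.

The compounds shown leave open which part of the entering group, whether the added amino nitrogen, the sulfonyl or the methyl on the ring, goes with the lower number, since all of them change together in this single step. They also leave open how the read-out would respond to a quite different group on this nitrogen, such as a carboxylic acid or an amine on a short chain.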